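Swapping Imidazole for Triazole on the Shared Core

The source may report more compounds than this note shows. Statements on the series, on what has been measured and on what is new or still open speak of the compounds shown alone.

Compound 1 `CC(C)(C(=O)O)C(c1ccc(Nc2ccc3ccccc3c2)cc1)n1ccnc1` was examined in an assay on isolated protein for inhibition of cytochrome P450 26A1 (Homo sapiens), read by scintillation counting (on this read-out lower numbers stand for stronger inhibition and higher numbers for weaker inhibition), where compound 1 gives 300 nM. Of the two numbers in hand, this is the highest. Its nearest neighbour is compound 2 `CC(C)NC(=O)C(C)(C)C(c1ccc(Nc2ccc3ccccc3c2)cc1)n1ccnc1`, and in this assay compound 2 gives 120 nM. For the measured compounds named here, the one recorded step, a 2.5-fold lower number from compound 1 to compound 2 (0.40 log units; beyond the scatter), concerns the carbonyl carbon, where an isopropylamino replaces a hydroxy.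

Compound 3 `CC(C)(C(=O)O)C(c1ccc(Nc2ccc3ccccc3c2)cc1)n1cncn1` has not yet been measured in this assay. It differs from compound 1 in one place: 1H-1,2,4-triazol-1-yl in place of 1H-imidazol-1-yl on a saturated chain carbon bound to an aromatic carbon and a saturated chain carbon. Going by the values given here, no measured step touches this azole change; the only step in hand, from the hydroxy to the isopropylamino on the carbonyl carbon, leaves that part of the molecule untouched and so says nothing about it. With nothing to lean on, the expected step is a 1.3-fold higher number from compound 1 to compound 3 (0.12 log units; within the scatter), which is not clearly beyond the scatter. Compound 3 is therefore estimated to give 400 nM in this assay, within a range from 120 nM to 1300 nM.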

Compound 3, half-maximal inhibitory concentration: > 1000 nM
Compound 3 was reported as a limit; the forecaster's own chance of this, stated with the estimate: 2%; middle value at least 2.5-fold (0.39 log units) from the limit.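

The azole on the saturated chain carbon is the part of the molecule that the earlier pair left untouched, and in this assay changing it gives an at least 3.3-fold higher number from compound 1 to compound 3 (0.52 log units; beyond the scatter). For the compounds shown here, the earlier step, a 2.5-fold lower number from compound 1 to compound 2 (0.40 log units; beyond the scatter), showed only that the number answers to the group on the carbonyl carbon; this one shows that it also answers to the azole, and in the opposite direction, with the 1H-imidazol-1-yl group giving the lower number of the pair and the 1H-1,2,4-triazol-1-yl group the higher. The value of compound 3, > 1000 nM, is a limit of the assay and not a number, so this change has a minimum size but no fixed one: the limit of > 1000 nM in this assay, at which 1 of the 3 values shown sits.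

The compounds shown leave open whether the 1H-1,2,4-triazol-1-yl group would raise the number in the same way on the isopropylamino amide of compound 2, where the azole has not been varied among the compounds in hand. They also leave open how a 1H-pyrazol-1-yl or a pyridinyl group would read on this same saturated chain carbon.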